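Swapping the Basic Amine Tail for a Hydroxypropyl Chain

The source may hold more compounds than are shown below. What is called first, only, known or untested is meant among the compounds shown, and "the series" means these compounds.

Compound 1 `N#Cc1nc2c(-c3nc4ccccc4[nH]3)c(N)n(CCN3CCCC3)c2nc1C#N`: in a functional assay on cells (Homo sapiens) for antiproliferative activity, read by MTT assay, with a stated time of 48 h (a higher number here means a weaker inhibitor, a lower number a stronger inhibitor), compound 1 gives > 50000 nM, which is a limit of the assay.
Compound 2 `CN1CCN(CCn2c(N)c(-c3nc4ccccc4[nH]3)c3nc(C#N)c(C#N)nc32)CC1`: in this assay compound 2 gives 9110 nM.
Compound 3 `N#Cc1nc2c(-c3nc4ccccc4[nH]3)c(N)n(CCO)c2nc1C#N`: in this assay compound 3 gives > 50000 nM, which is a limit of the assay.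

Compound 2 is the only one of the three with a number; the other two sit at the limit of > 50000 nM in this assay, at which 2 of the 3 values shown sit. Among the three, compound 2 therefore has the clearest activity in this assay, and the step from it is the one that can be read.

Compound 4 `N#Cc1nc2c(-c3nc4ccccc4[nH]3)c(N)n(CCCO)c2nc1C#N` differs from compound 2 by hydroxymethyl in place of 4-methylpiperazin-1-yl on a saturated chain carbon, two bonds along the chain from an aromatic nitrogen. The closest measured step is an at least 5.4-fold higher number from compound 2 to compound 3 (0.73 log units; beyond the scatter), in which the same group was replaced at the same place by hydroxy. Compound 4 carries the hydroxyl on a chain one carbon longer, so it resembles compound 3 more than compound 2. The step of an at least 5.4-fold lower number from compound 1 to compound 2 (0.73 log units; beyond the scatter) points the same way: the 4-methylpiperazin-1-yl group is the one that gives the lower number.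

Compound 4 is therefore expected to show a clearly higher number, a 5.5-fold higher number from compound 2 to compound 4 (0.74 log units; beyond the scatter), very likely ending at the limit. The estimate for compound 4 in this assay is 50000 nM, with a range from 15000 nM to 200000 nM.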

Compound 4, half-maximal inhibitory concentration: > 50000 nM
Compound 4: a limit, no number (the forecaster's own chance of this, stated with the estimate: 70%); the middle value sits exactly at the limit.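

In this assay, moving to the 3-hydroxypropyl chain of compound 4 does not recover the activity of the 2-(4-methylpiperazin-1-yl)ethyl chain of compound 2, giving an at least 5.4-fold higher number from compound 2 to compound 4 (0.73 log units; beyond the scatter). Compound 4 gives > 50000 nM, which is a limit of the assay, so the true size of this step may be larger than the printed figure. A terminal hydroxyl now sits at the limit on both chain lengths shown, and only the 4-methylpiperazin-1-yl group gives a number, while the pyrrolidin-1-yl group of compound 1 shows that a ring carrying nitrogen is not enough; the steps among compounds 1, 3 and 4 cannot be read, since both ends of each are limits: the limit of > 50000 nM in this assay, at which 3 of the 4 values shown sit.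

The compounds shown leave open whether a morpholin-4-yl or piperidin-1-yl group on the same chain would give a number, and so which part of the 4-methylpiperazin-1-yl group matters. They also leave open how a 3-(4-methylpiperazin-1-yl)propyl chain would read, which would separate the effect of chain length from that of the end group.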